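This account rests on a few compounds, and the source may have more. Where it says the series, first, only, none or still open, it means among the compounds named here.

Measured so far in a functional assay on MT4 cells (Homo sapiens) for cytotoxicity, read by MTT assay; on this read-out higher numbers stand for lower toxicity in this test and lower numbers for higher toxicity in this test:
- compound 1 `Cc1cc(C)cc(S(=O)(=O)c2c(C(=O)NN3CCOC3=O)[nH]c3ccc(Cl)cc23)c1`: 100 uM
- compound 2 `Cc1cc(C)cc(S(=O)(=O)c2c(C(=O)NNC3CCCCC3)[nH]c3ccc(Cl)cc23)c1`: > 100 uM (a limit)
- compound 3 `CC(=O)NNC(=O)c1[nH]c2ccc(Cl)cc2c1S(=O)(=O)c1cc(C)cc(C)c1`: > 100 uM (a limit)

Compound 3 stands at > 100 uM, which is a limit and not a number. It shares that position with one other compound: the limit of > 100 uM in this assay, at which 2 of the 3 values shown sit.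

Compound 4 `CCOC(=O)NNC(=O)c1[nH]c2ccc(Cl)cc2c1S(=O)(=O)c1cc(C)cc(C)c1` differs from compound 3 by ethoxy in place of methyl on a carbonyl carbon. In words, ethoxy replaces methyl on a carbonyl carbon, so acetyl becomes ethoxycarbonyl.

Among the measured compounds shown here, three measured steps bear on this end of the molecule: a number no lower from compound 1 to compound 2 (the limit leaves the size open), a number no lower from compound 1 to compound 3 (the limit leaves the size open) and a step that the two limits leave unreadable from compound 2 to compound 3. None has a readable size. For the measured compounds named here, the only numeric reading is compound 1 at 100 uM, and these three compounds give no lower number in this assay. No step beyond the usual scatter is therefore expected, and a further limit reading is the likeliest result.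

The expected step is a number no higher from compound 3 to compound 4 (the limit leaves the size open). For compound 4 the estimated value is 100 uM, with an expected range of 45 uM to 200 uM.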

Compound 4, half-maximal toxic concentration: 100 uM
Compound 4: the middle estimate sits on the measured number at the digits printed, and the stated range covers the measured number.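

In this assay, among the compounds shown here, compound 4 gives 100 uM, which adds a second numeric reading at this end of the molecule, and the one readable step is no change at the digits printed from compound 1 to compound 4 (within the scatter). The open-chain (ethoxycarbonyl)amino and the cyclic 2-oxo-1,3-oxazolidin-3-yl therefore read alike on an amide-type nitrogen in this assay. Two further steps have no readable size: a number no higher from compound 3 to compound 4 (the limit leaves the size open) and a number no higher from compound 2 to compound 4 (the limit leaves the size open). Their size cannot be read, because each of them starts from a limit: the limit of > 100 uM in this assay, at which 2 of the 4 values shown sit.

The compounds shown leave open how large the step for ethoxy in place of methyl on a carbonyl carbon is, or whether it has any size at all. Also open, as far as these compounds go, is how a longer chain such as butoxy, or a dimethylamino group, would read on that carbonyl carbon.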